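From Diethylamino to a Longer Amino Chain

The source may hold more compounds than are shown below. What is called first, only, known or untested is meant among the compounds shown, and "the series" means these compounds.

Of the compounds shown here, three built on a shared core have been tested in a functional assay on the whole organism for positive allosteric modulation, with Mus musculus as the target; a higher number here means that more compound is needed for the effect, a lower number that less compound is needed. Compound 1 (`CCC(=O)N(c1ccc(F)c(Cl)c1)C1CCCC1N(C)C`) gives 0.2 mg/kg. Compound 2 (`CCC(=O)N(c1ccc(C(=O)OC)cc1)C1CCCC1N(C)C`) gives > 50 mg/kg, which is a limit of the assay and not a number. Compound 3 (`CCC(=O)N(c1ccc(Cl)c(Cl)c1)C1CCCC1N(CC)CC`) gives 0.1 mg/kg, within the scatter of compound 1 at 0.2 mg/kg, so these two stand level at the low-dose end of the set.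

Compound 4 (`CCC(=O)N(c1ccc(Cl)c(Cl)c1)C1CCCC1N(C)CCCN(C)C`) carries (3-(dimethylamino)propyl)(methyl)amino in place of diethylamino on a saturated ring carbon, next to the ring atom that bears a large group: (3-(dimethylamino)propyl)(methyl)amino in place of diethylamino on a saturated ring carbon. For the measured compounds named here, no measured pair isolates this change, so the expectation rests on the structural change alone. A move beyond the scatter is expected in this assay, towards more compound being needed, and the estimated size is a 15-fold higher number from compound 3 to compound 4 (1.18 log units; beyond the scatter). For compound 4 the expected dose is 1.5 mg/kg, with an estimated range of 0.2 mg/kg to 15 mg/kg.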

Compound 4, dose for half-maximal effect: 4 mg/kg
Compound 4: middle estimate off by 2.7-fold (0.43 log units), on the low side, and the stated range covers the measured number.
By their numbers in this assay, from the lowest: compounds 3 and 1 (each within the scatter of the next); then compound 4. At a limit, above all of these: compound 2.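

Replacing diethylamino with (3-(dimethylamino)propyl)(methyl)amino on this saturated ring carbon changes the amino group alone, and in this assay this brings a 40-fold higher number from compound 3 to compound 4 (1.60 log units; beyond the scatter) in a single move. The earlier compounds shown here did not show this: here the dose depends on which amino group sits at this position, even with the rest of the molecule unchanged. The entering group has 8 heavy atoms against 5 and 2 hydrogen-bond acceptors against 1, yet compound 4 still gives a measurable dose of 4 mg/kg in this assay.

As far as these compounds go, it remains open whether the longer chain or its terminal dimethylamino accounts for the step, and a propyl chain ending in a hydroxyl group on the same carbon would tell these apart. Nothing among the data shown explains the size of this step.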